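Swapping 2-hydroxy-5-nitrophenyl for 6-hydroxyhexyl on an amine nitrogen

The source may report more compounds than this note shows. Statements on the series, on what has been measured and on what is new or still open speak of the compounds shown alone.

Values in an ADME assay on A549 cells (Homo sapiens) for cytotoxicity, read by CellTiter-Glo; a lower number here means that less compound is tolerated, a higher number that more compound is tolerated:
- Compound 1 `C#CCNCC(O)COc1ccc2c(C)c(Cc3ccccc3)c(=O)oc2c1`: 95500 nM
- Compound 2 `Cc1c(Cc2ccccc2)c(=O)oc2cc(OCC(O)CNc3cc([N+](=O)[O-])ccc3O)ccc12`: > 100000 nM (a limit of the assay, not a number)

Compound 2 gives no exact number, and its position is only a limit: the limit of > 100000 nM in this assay, at which 1 of the 2 values shown sits. Compound 3 `Cc1c(Cc2ccccc2)c(=O)oc2cc(OCC(O)CNCCCCCCO)ccc12` carries 6-hydroxyhexyl in place of 2-hydroxy-5-nitrophenyl on an amine nitrogen. One measured step changes the group on this nitrogen: an at least 1.0-fold higher number from compound 1 to compound 2 (0.01 log units; that floor lies within the scatter). That step gives only a floor, within the scatter, so no change beyond the scatter is expected in this assay. The expected step is an at least 1.4-fold lower number from compound 2 to compound 3 (0.15 log units; that floor lies within the scatter). For compound 3 the estimate is 70000 nM, with an expected range of 30000 nM to 100000 nM.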

Compound 3, half-maximal cytotoxic concentration: 40300 nM
Compound 3: middle estimate off by 1.7-fold (0.24 log units), on the high side; low and high end bracket the measured number.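

In this assay, the group on this amine nitrogen can shift the read-out beyond the scatter, which the earlier step between compounds with a limit could not show: 6-hydroxyhexyl in place of 2-hydroxy-5-nitrophenyl gives an at least 2.4-fold lower number from compound 2 to compound 3 (0.39 log units; beyond the scatter), and the same chain in place of propargyl gives a 2.4-fold lower number from compound 1 to compound 3 (0.37 log units; beyond the scatter). Compound 2 gives a limit and not a number, so the first of these steps is only a floor: the limit of > 100000 nM in this assay, at which 1 of the 3 values shown sits.

As far as these compounds go, whether the chain's length or its end hydroxyl goes with the lower number stays open. A plain hexyl chain, a shorter hydroxyalkyl chain or a chain ending in an amine would help separate the two.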